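A few compounds are considered here, and "the series" means these few. Any claim that something is new, unique, unknown or untested is made for them only; others in the source may bear on it.

Measured compounds:
- compound 1, `C[C@H](NC(=O)CN(c1nc(Cl)nc2[nH]cnc12)C1CC1)C(=O)OCc1ccccc1`: 36.1%
- compound 2, `O=C(CN(c1ncnc2c1ncn2C1CCCCO1)C1CC1)N[C@@H](CCC(=O)OCc1ccccc1)C(=O)OCc1ccccc1`: 20.7%
- compound 3, `O=C(CN(c1nc(Cl)nc2[nH]cnc12)C1CC1)N[C@@H](CO)C(=O)O`: 39%

All three were tested in a functional assay on the whole organism (Tail, strain ICR) with Mus musculus as the target, in the tail flick test, with a stated time of 120 min, at a dose of 25 umol/kg by the oral route; on this read-out higher numbers stand for a stronger effect at the one dose given and lower numbers for a weaker effect. Compound 3 gives the highest of the three numbers, 39%. Its nearest neighbour on the numbers is compound 1, whose 36.1% lies within the usual scatter, so the two cannot be set in order. Compound 2, with 20.7%, sits clearly lower, a gap that goes beyond the scatter.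

The next compound, compound 4, `CC(C)C[C@H](NC(=O)CN(c1nc(Cl)nc2[nH]cnc12)C1CC1)C(=O)O`, has not yet been measured in this assay. It is built from compound 3 by one change: isopropyl in place of hydroxy on a saturated chain carbon, two bonds along the chain from an amide-type nitrogen and a carbonyl carbon. The hydroxy leaves and an isopropyl enters, so the hydroxymethyl side chain of compound 3 becomes an isobutyl in compound 4, while the rest of the molecule stays the same.

Within the data shown here, no pair of measured compounds differs by exactly this kind of change, so there is no measured step to lean on. The three numbers give no hint that a change of this sort pushes the read-out strongly in either direction, and the expectation is a step of a number 1 percentage points higher from compound 3 to compound 4 (within the scatter), which stays inside the scatter. Compound 4 is therefore estimated at 40%, with a range from 20% to 60%.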

Compound 4, a percentage reported as activity, at one dose (the size of the read-out at that dose, not a potency): 18.7%
For compound 4 the middle estimate is 21.3 percentage points above the measured one, outside the stated range (below it).
By their numbers in this assay, from the lowest: compounds 4 and 2 (each within the scatter of the next); then compounds 1 and 3 (each within the scatter of the next).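

In this assay, the group on this saturated chain carbon turns out to matter: replacing the hydroxymethyl side chain with isobutyl, with the rest of the molecule unchanged, gives a number 20.3 percentage points lower from compound 3 to compound 4 (beyond the scatter). Among these compounds, this pair is the first to differ in one place only, so it offers the first direct reading of a single change, and here that change clearly lowers the effect seen at the one dose given. Nothing available explains why the number falls in this whole-animal test.

The hydroxy leaves and the isopropyl enters in the same step, so this pair cannot tell whether losing the one or gaining the other accounts for the fall. A side chain such as aminomethyl or methoxymethyl on the same carbon would help separate the two, and would show whether the higher number is specific to hydroxymethyl or is shared by other groups at this position.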